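Adding a Methyl Group: Does the Maximal Response Change?

A few compounds are considered here, and "the series" means these few. Any claim that something is new, unique, unknown or untested is made for them only; others in the source may bear on it.

In an in vitro functional assay on 1321-N1 cells for agonist activity at Free fatty acid receptor 1 (Homo sapiens), read by fluorescence, spectrophotometry and calcium flux (a higher number here means a larger maximal response, a lower number a smaller maximal response), compound 1 `O=C(O)CCc1ccc(C#Cc2ccnc(F)c2)cc1` gives 98%. Compound 2 `O=C(O)CCc1ccc(C#Cc2ccncc2)cc1` differs from compound 1 by hydrogen in place of fluoro on an aromatic carbon; in this assay compound 2 gives 100%, and the step of a number 2 percentage points higher from compound 1 to compound 2 (within the scatter) is small. Compound 3 `Cc1c(C#Cc2ccc(CCC(=O)O)cc2)ccnc1F` carries the change methyl in place of hydrogen on an aromatic carbon relative to compound 1; in this assay compound 3 gives 101%, and the step of a number 3 percentage points higher from compound 1 to compound 3 (within the scatter) is small as well. The three measured values lie close together, and no difference among them goes beyond the usual scatter of this kind of measurement.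

Compound 4 `Cc1cc(C#Cc2ccc(CCC(=O)O)cc2)ccn1` has not yet been measured in this assay. It differs from compound 2 by methyl in place of hydrogen on an aromatic carbon. Among the measured compounds shown here, this is the same kind of change as the one from compound 1 to compound 3, but not the same: in compound 3 the methyl sits ortho to a fluoro group, ortho to a large group and two atoms from the ring nitrogen, whereas in compound 4 it sits next to the ring nitrogen and meta to a large group. The expected step is no change at the digits printed from compound 2 to compound 4 (within the scatter), set beside the earlier a number 3 percentage points higher from compound 1 to compound 3 (within the scatter), because a number 3 percentage points higher from compound 1 to compound 3 (within the scatter) stayed within the scatter and the measured values of compound 1, compound 2 and compound 3 all sit near the reference response. Compound 4 is therefore estimated to give about 100%, with likely bounds of 90% and 110%.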

Compound 4, largest response reached (reported as efficacy), in percent of the reference or control that the assay uses: 102%
The estimate for compound 4 lay 2 percentage points below the measured number; the measured number falls inside the stated range.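

In this assay, methyl in place of hydrogen on an aromatic carbon gives a number 2 percentage points higher from compound 2 to compound 4 (within the scatter), and methyl in place of fluoro gives a number 4 percentage points higher from compound 1 to compound 4 (within the scatter). Methyl in place of hydrogen therefore behaves alike on the two cores examined here: the same change on two cores in this assay, a number 3 percentage points higher (within the scatter) from compound 1 to compound 3 and a number 2 percentage points higher (within the scatter) from compound 2 to compound 4, 1 percentage points apart, within the scatter of two such steps This agreement shows only that the change can be carried between these two closely related cores without a detectable shift in maximal response; it does not show that the same would hold on a different core, and the methyl does not stand at the same place in compound 3 and compound 4, so the comparison does not isolate a single position, nor does a largest response tell how much compound is needed to reach it.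

The compounds shown leave open whether a larger group, such as ethyl, methoxy or an amine, would keep the maximal response when placed on the same aromatic carbon as the methyl of compound 4. They also leave open whether the response would hold with a primary amide in place of the carboxylic acid that all four compounds carry.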